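Acyl variation on the amino-substituted core

The compounds below may be only part of what the source reports. "The series", "measured", "known", "first", "only" and "open" are said of these compounds alone.

Measured compounds:
compound 1 `Cc1nc2c(OCc3ccccc3)cccn2c1N`, 99%
compound 2 `Cc1nc2c(OCc3ccccc3)cccn2c1CN`, 46%
compound 3 `CC(=O)Nc1c(C)nc2c(OCc3ccccc3)cccn12`, 93%

In a functional assay on the whole organism with Rattus norvegicus as the target, at a dose of 40 mg/kg by the intraperitoneal route (a higher number here means more inhibition at the dose given (going by the name of the read-out), a lower number less inhibition), compound 1 gives 99%, compound 2 gives 46% and compound 3 gives 93%. Compound 3 stands second highest of the three, within the scatter of compound 1 and far above compound 2: a number 6 percentage points lower from compound 1 to compound 3 (within the scatter), whereas a number 53 percentage points lower from compound 1 to compound 2 (beyond the scatter) and a number 47 percentage points higher from compound 2 to compound 3 (beyond the scatter).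

Compound 4 `Cc1nc2c(OCc3ccccc3)cccn2c1NC(=O)OCc1ccccc1` differs from compound 3 by benzyloxy in place of methyl on a carbonyl carbon. Among the measured compounds shown here, no measured step changes the group on the carbonyl carbon, so the only step that bears on it is a number 6 percentage points lower from compound 1 to compound 3 (within the scatter), which shows that acetyl in place of hydrogen on the nitrogen on the aromatic ring leaves the inhibition essentially unchanged. The present change is larger than that one; the expectation is therefore a step of a number 8 percentage points lower from compound 3 to compound 4 (within the scatter) in this assay, at most a modest loss and possibly none beyond the scatter. Compound 4 is estimated at 85%, between 60% and 99%.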

Compound 4, a percentage reported as inhibition, in the whole organism at one dose (the size of the read-out at that dose, not a potency): 8%
For compound 4 the middle estimate is 77 percentage points above the measured one; measured number below the stated range.
By their numbers in this assay, from the lowest: compound 4; then compound 2; then compounds 3 and 1 (each within the scatter of the next).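

Benzyloxy in place of methyl on a carbonyl carbon whose other neighbour is the amide-type nitrogen gives a number 85 percentage points lower from compound 3 to compound 4 (beyond the scatter) in this assay. The earlier step of a number 6 percentage points lower from compound 1 to compound 3 (within the scatter) therefore describes acetyl on that nitrogen only and does not extend to every carbonyl group placed there, since the group on the carbonyl carbon can decide the read-out in this series. The compounds shown offer no measurement that accounts for this loss.

The entering benzyloxy brings its oxygen and its six-membered aromatic ring together, so these two parts cannot be told apart here. Methoxy on the same carbonyl carbon would test the oxygen without the ring, and benzyl would test the ring without the oxygen.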